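Chloro for trifluoromethyl in a urea series

The compounds below may be only part of what the source reports. "The series", "measured", "known", "first", "only" and "open" are said of these compounds alone.

Two ureas built on a shared core have been measured in a physicochemical assay for solubility, at pH 7.4; a lower number here means a less soluble compound, a higher number a more soluble compound. Compound 1, `Cc1cc(NC(=O)Nc2cc(Cl)cc(Cl)c2)c2ccccc2n1`, gives 800 nM in this assay. Compound 2, `Cc1cc(NC(=O)Nc2cccc(C(F)(F)F)c2)c2ccccc2n1`, gives 100 nM in this assay. Compound 2 therefore stands at the lowest of the two numbers, and the gap to its nearest neighbour, compound 1, lies beyond the usual scatter of this assay.

Compound 3, `Cc1cc(NC(=O)Nc2cccc(Cl)c2)c2ccccc2n1`, has not yet been measured. It differs from compound 2 in one place: chloro in place of trifluoromethyl on an aromatic carbon. Within the data shown here, no measured pair differs in exactly this way, so no measured step can be taken as a direct guide. What can be said is that compound 1, which carries two chloro groups on its phenyl ring, gives 800 nM, a higher number than compound 2. On that basis compound 3 is expected to move upward from compound 2, by a step of a 10-fold higher number from compound 2 to compound 3 (1.00 log units; beyond the scatter) that should lie beyond the scatter. For compound 3 the estimate in this assay is 1000 nM, with a range from 300 nM to 3000 nM.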

Compound 3, solubility: 800 nM
Compound 3: middle estimate off by 1.3-fold (0.10 log units), on the high side; the measured number falls inside the stated range.
By their numbers in this assay, from the lowest: compound 2; then compounds 1 and 3 (each within the scatter of the next).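

In this assay, chloro in place of trifluoromethyl on this aromatic carbon gives an 8.0-fold higher number from compound 2 to compound 3 (0.90 log units; beyond the scatter) as a measured step, so this single exchange is now seen directly and lies beyond the scatter. The other one-place change gives a different picture: hydrogen in place of chloro on an aromatic carbon gives no change at the digits printed from compound 1 to compound 3 (within the scatter) and stays within the scatter, so the second chloro of compound 1 makes no readable difference in this pair. Among these three compounds, the number therefore moves with the exchange of trifluoromethyl for chloro but not with the removal of that one chloro, though each reading rests on a single pair. No measurement shown here explains the size of either step. On these data alone, it remains open where an amine, a carboxylic acid or a methoxy group on the same aromatic carbon would fall in this assay relative to compound 2 and compound 3, and what hydrogen in place of the remaining chloro of compound 3 would do.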